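Swapping the benzyl arm for a pyridine on the amine

The source may report more compounds than this note shows. Statements on the series, on what has been measured and on what is new or still open speak of the compounds shown alone.

Compound 1 `c1ccc(CNCC2CCN(CCCc3c[nH]c4ccc(-n5cnnc5)cc34)CC2)cc1` gives 28 nM in an assay on CHO cells for displacement of a labelled ligand from 5-hydroxytryptamine receptor 1B (Homo sapiens) (on this read-out higher numbers stand for weaker inhibition and lower numbers for stronger inhibition), the lowest of the three numbers measured. Compound 2 `CN(Cc1cccs1)C1CCN(CCCc2c[nH]c3ccc(-n4cnnc4)cc23)CC1` gives 140 nM, and compound 3 `CN(Cc1ccco1)C1CCN(CCCc2c[nH]c3ccc(-n4cnnc4)cc23)CC1` gives 89 nM. The steps of a 5.0-fold higher number from compound 1 to compound 2 (0.70 log units; beyond the scatter) and a 3.2-fold higher number from compound 1 to compound 3 (0.50 log units; beyond the scatter) show that reworking the amine end weakened binding modestly, while a 1.6-fold lower number from compound 2 to compound 3 (0.20 log units; within the scatter) is within the scatter. Compound 4 `c1ccc(NCC2CCN(CCCc3c[nH]c4ccc(-n5cnnc5)cc34)CC2)nc1` carries pyridin-2-yl in place of benzyl on an amine nitrogen. Among the measured compounds shown here, no measured step matches this change; the two steps that alter the amine region both weakened binding by a modest amount, so a modest weakening is also expected here, though with wide uncertainty. Compound 4 is therefore estimated at 70 nM, between 20 nM and 250 nM, meaning an expected step of a 2.5-fold higher number from compound 1 to compound 4 (0.40 log units; beyond the scatter).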

Compound 4, half-maximal inhibitory concentration: 3.3 nM
Compound 4: middle estimate off by 21-fold (1.33 log units), on the high side; the measured number lies below the stated range.
By their numbers in this assay, from the lowest: compound 4; then compound 1; then compounds 3 and 2 (each within the scatter of the next).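

Pyridin-2-yl in place of benzyl on the amine nitrogen gives an 8.5-fold lower number from compound 1 to compound 4 (0.93 log units; beyond the scatter) and so strengthens binding, whereas both earlier changes to the amine end weakened it. The gaps to the other two compounds are wider, with a 27-fold lower number from compound 3 to compound 4 (1.43 log units; beyond the scatter) and a 42-fold lower number from compound 2 to compound 4 (1.63 log units; beyond the scatter) across changes that alter more of the arm. No measurement shown accounts for this gain.

From the compounds shown here alone, the change both removes a carbon and adds a ring nitrogen, so which of these matters remains open. A plain phenyl on the same amine nitrogen would separate the two.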